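Replacing trifluoromethyl with fluoro on compound 2

The compounds below may be only part of what the source reports. "The series", "measured", "known", "first", "only" and "open" are said of these compounds alone.

Measured in an ADME assay on Vero cells (Chlorocebus sabaeus) for cytotoxicity, with a stated time of 72 h (on this read-out higher numbers stand for weaker inhibition and lower numbers for stronger inhibition), are two compounds:
- compound 1 `O=C(CCN1CCN(c2ccc([N+](=O)[O-])cc2)CC1)c1csc2ccccc12` gives 1710000 nM
- compound 2 `O=C(CCN1CCN(c2ccc(C(F)(F)F)cc2)CC1)c1csc2ccc(F)cc12` gives 896000 nM

On these numbers compound 2 sits within the usual scatter of compound 1 and no order can be drawn between them. On these data alone, compound 3 `O=C(CCN1CCN(c2ccc(F)cc2)CC1)c1csc2ccc(F)cc12` differs from compound 2 by fluoro in place of trifluoromethyl on an aromatic carbon and its value is still open. Going by the values given here, no measured step speaks to this change in this assay so no shift beyond the scatter is expected. The expected outcome is a 1.2-fold higher number from compound 2 to compound 3 (0.09 log units; within the scatter) and this stays within the scatter. For compound 3 1100000 nM is the estimated value and 450000 nM to 2500000 nM the expected range.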

Compound 3, half-maximal inhibitory concentration: 759000 nM
Estimate against measurement, compound 3: 1.4-fold (0.16 log units) above; the range from low to high includes it.
By their numbers in this assay, from the lowest: compounds 3, 2 and 1 (each within the scatter of the next, the first and the last beyond it).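

In this assay, fluoro in place of trifluoromethyl on an aromatic carbon para to a large group gives a 1.2-fold lower number from compound 2 to compound 3 (0.07 log units; within the scatter), the only single-place step shown at this position. On this read-out, the 4-(trifluoromethyl)phenyl and 4-fluorophenyl forms therefore cannot be told apart, as the step stays within the scatter. No evidence available here bears on the reason for this result.

The compounds shown leave open whether an amine or a carboxylic acid on this aromatic carbon would move the number beyond the scatter.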